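The compounds below may be only part of what the source reports. "The series", "measured", "known", "first", "only" and "open" are said of these compounds alone.

In a functional assay on HOS-TE85 cells (Homo sapiens) for inhibition, read by CCK-8 assay, with a stated time of 72 h (a lower number here means a stronger inhibitor, a higher number a weaker inhibitor), compound 2 `O=C(NCCCCc1ccccc1)c1cccc(C2SCC(=O)N2c2cccc(F)c2)c1` gives 32.4 nM, the lowest of the two numbers recorded so far. Compound 1 `CC1SC(c2cccc(C(=O)NCCCCc3ccccc3)c2)N(c2ccc(C3CC3)cc2)C1=O` gives 191 nM in this assay, a gap from compound 2 that lies well beyond the usual scatter of repeated measurements. Compound 3 `COc1ccccc1N1C(=O)CSC1c1cccc(C(=O)NCCCCn2cncn2)c1` reaches only a limit of this assay, recorded as > 1000 nM; the note the limit of > 1000 nM in this assay, at which 1 of the 3 values shown sits, records that one of the three values sits at that limit.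

Compound 4 `CC(F)(F)c1cccc(N2C(=O)CSC2c2cccc(C(=O)NCCCCc3ccccc3)c2)c1` has not yet been measured in this assay. It differs from compound 2 in a single place: 1,1-difluoroethyl in place of fluoro on an aromatic carbon. Among the measured compounds shown here, no two measured compounds differ from each other in only one place, so no step of this kind has been observed, and the size of the change can only be anticipated. The expectation is a step toward a somewhat higher number, of a size that may not exceed the scatter, as a 1.9-fold higher number from compound 2 to compound 4 (0.27 log units; within the scatter). Compound 4 is therefore expected to give about 60 nM in this assay, with a likely range from 20 nM to 200 nM.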

Compound 4, half-maximal inhibitory concentration in the HOS-TE85 assay: 29.1 nM
Compound 4: the middle estimate sits 2.1-fold (0.31 log units) above what was measured; low and high end bracket the measured number.
By their numbers in the HOS-TE85 assay, from the lowest: compounds 4 and 2 (each within the scatter of the next); then compound 1. At a limit, above all of these: compound 3.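

In the HOS-TE85 assay, the position on this aromatic carbon, meta to a large group, accepts 1,1-difluoroethyl in place of fluoro with a 1.1-fold lower number from compound 2 to compound 4 (0.05 log units; within the scatter), so the larger group brings no change that can be told from the scatter. In a physicochemical assay for solubility, read by turbidimetry, measured as kinetic solubility, at pH 7.4 (on this read-out higher numbers stand for higher solubility and lower numbers for lower solubility), compound 2 gives 10000 nM and compound 4 gives 2000 nM, so the two assays part ways for this change. Here, 1,1-difluoroethyl in place of fluoro comes with lower solubility and no readable shift in the HOS-TE85 assay: the measured solubility of compound 2, 10000 nM, and of compound 4, 2000 nM, a 5.0-fold lower number (0.70 log units; beyond the scatter)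

The compounds shown leave open whether an amine or a carboxylic acid on this aromatic carbon would keep the number in the HOS-TE85 assay while giving higher solubility. They also leave open what a longer fluorinated chain at this place would do to either number.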